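The source may report more compounds than this note shows. Statements on the series, on what has been measured and on what is new or still open speak of the compounds shown alone.

Measured so far: compound 1 `O[C@@H]1[C@@H](O)[C@H](Oc2ccc(S)c3ccccc23)OC[C@H]1O` with 55 uM; compound 2 `O[C@@H]1[C@@H](O)[C@H](Oc2cccc3c(S)cccc23)OC[C@H]1O` with 110 uM; compound 3 `O[C@@H]1[C@@H](O)[C@H](Oc2ccc3cc(S)ccc3c2)OC[C@H]1O` with 135 uM.

In a functional assay on T-24 cells (Homo sapiens) for antiproliferative activity, read by crystal violet staining, with a stated time of 96 h (on this read-out lower numbers stand for an effect already at smaller amounts and higher numbers for an effect only at larger amounts of compound), compound 2 stands second highest of the three numbers. Its nearest neighbour is compound 3, whose value lies within the scatter of that of compound 2, and the furthest is compound 1, also within the scatter. The three values thus give no order among them.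

Compound 4 `CCCSc1cccc2c(O[C@@H]3OC[C@@H](O)[C@H](O)[C@H]3O)cccc12` differs from compound 2 by one change: propyl in place of hydrogen on a sulfur. Among the measured compounds shown here, no measured pair shows this step, so its size is open. A small step toward lower numbers in this assay is expected, not clearly beyond the scatter. For compound 4 the estimate is 70 uM with a range of 25 uM to 200 uM, which means an expected step of a 1.6-fold lower number from compound 2 to compound 4 (0.20 log units; within the scatter).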

Compound 4, concentration for half-maximal effect: 40 uM
Beside the measured number, compound 4's estimate is 1.8-fold (0.24 log units) above it, and the stated range covers the measured number.
By their numbers in this assay, from the lowest: compounds 4, 1, 2 and 3 (each within the scatter of the next, the first and the last beyond it).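

Putting propyl in place of hydrogen on the sulfur gives, in this assay, a 2.8-fold lower number from compound 2 to compound 4 (0.44 log units; beyond the scatter), a modest step and the only one here beyond the scatter. The sulfur therefore need not carry its hydrogen for this effect, and the added chain does not cost activity. Nothing in the data explains the step.

From the compounds shown here alone, whether methyl, a longer chain, an amine or a carboxylic acid on this sulfur would move the number remains open. So does whether propylsulfanyl would give a similar step in compound 1 or compound 3.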